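This account rests on a few compounds, and the source may have more. Where it says the series, first, only, none or still open, it means among the compounds named here.

Of the compounds shown here, three have been measured in an assay on liver for inhibition of sterol O-acyltransferase 1 (Rattus norvegicus), using microsomes; on this read-out lower numbers stand for stronger inhibition and higher numbers for weaker inhibition.
Compound 1 `CC(C)c1cccc(C(C)C)c1NS(=O)(=O)NC(=O)Oc1c(C(C)(C)C)cccc1C(C)(C)C` gives 16800 nM.
Compound 2 `COc1cc(C(C)(C)C)c(OC(=O)NS(=O)(=O)Nc2c(C(C)C)cccc2C(C)C)c(C(C)(C)C)c1` gives 15000 nM.
Compound 3 `COc1cccc(OC)c1OS(=O)(=O)NC(=O)Oc1c(C(C)C)cccc1C(C)C` reaches only a limit of this assay, > 50000 nM.

From compound 1 to compound 2 the change is methoxy in place of hydrogen on an aromatic carbon, and the step is a 1.1-fold lower number from compound 1 to compound 2 (0.05 log units; within the scatter). The difference between the core of compound 1 and the core of compound 3 is not broken down here. Compound 4 `COc1cc(OC)c(OS(=O)(=O)NC(=O)Oc2c(C(C)C)cccc2C(C)C)c(OC)c1` has not yet been measured; it arises from compound 3 by the same kind of change, (methoxy in place of hydrogen on an aromatic carbon), the place now lying meta to two methoxy groups rather than two tert-butyl groups. Because the earlier step of a 1.1-fold lower number from compound 1 to compound 2 (0.05 log units; within the scatter) lay within the scatter, the step from compound 3 to compound 4 in this assay is expected to be about a step that the limit leaves unreadable from compound 3 to compound 4. Because compound 3 already sits at the limit of > 50000 nM in this assay, at which 1 of the 3 values shown sits, compound 4 is estimated to give roughly 60000 nM, most likely again only a limit.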

Compound 4, half-maximal inhibitory concentration: > 50000 nM
Compound 4: a limit, no number; the forecaster's own chance of this, stated with the estimate: 85%; the middle value does not contradict the limit.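

Compound 3 and compound 4 both give only a limit, so no step between them can be read: the limit of > 50000 nM in this assay, at which 2 of the 4 values shown sit.

The compounds shown leave open whether methoxy in place of hydrogen changes anything on the core of compound 3 in this assay.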